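Cytotoxicity notes: the step from compound 3 to compound 4

The compounds below may be only part of what the source reports. "The series", "measured", "known", "first", "only" and "open" are said of these compounds alone.

In an ADME assay on MT4 cells (Homo sapiens) for cytotoxicity, read by MTT assay (on this read-out higher numbers stand for lower toxicity in this test and lower numbers for higher toxicity in this test), compound 1 `O=C1c2ccccc2C(=O)N1CCOC(=S)N(C(=O)c1cccc(F)c1F)c1ccc(Cl)cc1` gives 58000 nM, compound 2 `O=C1c2ccccc2C(=O)N1CCOC(=S)N(C(=O)c1c(Cl)cccc1Cl)c1ccc(Cl)cc1` gives 20000 nM and compound 3 `O=C1c2ccccc2C(=O)N1CCOC(=S)N(C(=O)c1ccc(Cl)c([N+](=O)[O-])c1)c1ccc(Cl)cc1` gives 48000 nM. Compound 3 is second highest of these three numbers, but its place relative to compound 1 rests on a 1.2-fold lower number from compound 1 to compound 3 (0.08 log units; within the scatter), which is within the scatter. Its separation from compound 2 is clearer, at a 2.4-fold higher number from compound 2 to compound 3 (0.38 log units; beyond the scatter).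

Compound 4 `O=C1c2ccccc2C(=O)N1CCOC(=S)N(C(=O)c1ccc2ccccc2c1)c1ccc(Cl)cc1` has naphthalen-2-yl in place of 4-chloro-3-nitrophenyl on a carbonyl carbon. All three measured steps change the group at this same place, so all bear on the question, although none involves naphthalen-2-yl. The largest is a 2.9-fold lower number from compound 1 to compound 2 (0.46 log units; beyond the scatter), which is only modest. Only a small or modest change is therefore anticipated, with no firm direction. The expected step is a 1.3-fold lower number from compound 3 to compound 4 (0.10 log units; within the scatter), which leans slightly downward and is not expected to clear the scatter. For compound 4, the estimated value is 38000 nM, with an expected range of 17000 nM to 80000 nM.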

Compound 4, half-maximal cytotoxic concentration: 37000 nM
The estimate for compound 4 lay 1.0-fold (0.01 log units) above the measured number, and the stated range covers the measured number.
By their numbers in this assay, from the lowest: compounds 2, 4, 3 and 1 (each within the scatter of the next, the first and the last beyond it).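

Replacing 4-chloro-3-nitrophenyl with naphthalen-2-yl on the carbonyl carbon removes the hydrogen-bond acceptors of the leaving group and adds a second six-membered aromatic ring of carbon only, yet in this assay the result is a 1.3-fold lower number from compound 3 to compound 4 (0.11 log units; within the scatter) and the number stays within the scatter. Compound 4 also shows a 1.9-fold higher number from compound 2 to compound 4 (0.27 log units; within the scatter) and a 1.6-fold lower number from compound 1 to compound 4 (0.20 log units; within the scatter) as steps within the scatter, so the only gaps beyond the scatter remain those separating compound 2 from compound 1 and compound 3. No measurement on hand explains these numbers.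

The groups shown at this position are all aromatic, so the effect of a saturated cyclohexyl group, an amine or a carboxylic acid here remains open. Going by these compounds, whether the lower number of compound 2 is specific to 2,6-dichlorophenyl also remains open, as that group appears only once.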